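The source may report more compounds than this note shows. Statements on the series, on what has been measured and on what is new or still open speak of the compounds shown alone.

Measured compounds, with the values given in an ADME assay on L02 cells (Homo sapiens) for cytotoxicity, read by MTT assay, with a stated time of 24 h; on this read-out higher numbers stand for weaker inhibition and lower numbers for stronger inhibition:

compound 1, `O=C1/C(=C/c2cccc([N+](=O)[O-])c2)CN(S(=O)(=O)c2ccc(F)cc2)C/C1=C\c1ccccc1F`, 17000 nM
compound 2, `N#Cc1ccc(/C=C2\CN(S(=O)(=O)c3ccc(F)cc3)C/C(=C\c3ccccc3F)C2=O)cc1`, 21900 nM
compound 3, `COc1cc(/C=C2\CN(S(=O)(=O)c3ccc(NC(C)=O)cc3)C/C(=C\c3cccc([N+](=O)[O-])c3)C2=O)cc(OC)c1OC`, 15600 nM

Compound 1 and compound 2 share a core; the one place where they differ is 4-cyanophenyl in place of 3-nitrophenyl on a double-bonded chain carbon bound to a double-bonded ring carbon. In this assay the step of a 1.3-fold higher number from compound 1 to compound 2 (0.11 log units; within the scatter), so the two numbers cannot be told apart. Compound 3 carries a different core; the difference between the core of compound 1 and the core of compound 3 is not broken down here. The numbers of compound 3 and compound 1 lie within the scatter of each other, as do those of compound 3 and compound 2, so no order among the three measured compounds can be read from these data.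

Compound 4, `COc1cc(/C=C2\CN(S(=O)(=O)c3ccc(NC(C)=O)cc3)C/C(=C\c3ccc(C#N)cc3)C2=O)cc(OC)c1OC`, has not been measured. Among the measured compounds shown here, it differs from compound 3 in one place, (4-cyanophenyl in place of 3-nitrophenyl on a double-bonded chain carbon bound to a double-bonded ring carbon), which is the same change as the one from compound 1 to compound 2, made on the core of compound 3. For the measured compounds named here, only that one pair shows what this change does, and there it gave a 1.3-fold higher number from compound 1 to compound 2 (0.11 log units; within the scatter). For compound 4 the step from compound 3 is therefore expected to be a 1.3-fold higher number from compound 3 to compound 4 (0.11 log units; within the scatter), resting on the step of a 1.3-fold higher number from compound 1 to compound 2 (0.11 log units; within the scatter) and on the value of compound 3, 15600 nM. The estimate for compound 4 in this assay is 20000 nM, expected to fall between 10000 nM and 40000 nM.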

Compound 4, half-maximal inhibitory concentration: 13600 nM
Beside the measured number, compound 4's estimate is 1.5-fold (0.17 log units) above it; the range from low to high includes it.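

In this assay, 4-cyanophenyl in place of 3-nitrophenyl on a double-bonded chain carbon bound to a double-bonded ring carbon gives a 1.1-fold lower number from compound 3 to compound 4 (0.06 log units; within the scatter). Set beside the earlier pair, the two steps cannot be told apart: the same change on two cores in this assay, a 1.3-fold higher number (0.11 log units; within the scatter) from compound 1 to compound 2 and a 1.1-fold lower number (0.06 log units; within the scatter) from compound 3 to compound 4, 1.5-fold (0.17 log units) apart, within the scatter of two such steps. This shows that on these two cores the change leaves the numbers within the scatter both times, so the readings agree with carrying it from one core to the other; it does not show that the change has an effect of any size or direction, as neither step stands clear of the scatter, and two pairs give no rule for a further core.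

The compounds shown leave open whether a phenyl carrying an amine or a carboxylic acid on the same double-bonded chain carbon would give a step beyond the scatter in this assay. Also open, from the compounds shown here alone, is whether the step between 3-nitrophenyl and 4-cyanophenyl stays within the scatter on a core other than the core of compound 1 and the core of compound 3.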